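The compounds below may be only part of what the source reports. "The series", "measured", "known", "first", "only" and "open" are said of these compounds alone.

Compounds measured so far in an ADME assay on L1210/0 cells (Mus musculus) for cytotoxicity, with a stated time of 48 h; on this read-out higher numbers stand for weaker inhibition and lower numbers for stronger inhibition:
compound 1 `O=c1[nH]c(=O)n([C@@H]2CCC[C@H]2CO)cc1I` gives only the limit > 200000 nM.
compound 2 `O=c1ccn([C@@H]2CCC[C@H]2CO)c(=O)[nH]1` gives only the limit > 200000 nM.
compound 3 `O=c1[nH]c(=O)n(CC2CCC(CO)C2)cc1I` gives only the limit > 200000 nM.

Compound 1 and compound 2 differ by hydrogen in place of iodo on an aromatic carbon; the step that the two limits leave unreadable from compound 1 to compound 2 cannot be read because both sit at the limit of > 200000 nM in this assay, at which 3 of the 3 values shown sit. The core of compound 3 differs from the core of compound 1, and that difference is not broken down here.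

Compound 4 `O=c1ccn(CC2CCC(CO)C2)c(=O)[nH]1` is not yet measured in this assay. It differs from compound 3 by hydrogen in place of iodo on an aromatic carbon. The surroundings of the place are not identical to those of the earlier pair: in compound 3 the carbon is meta to a group of 8 heavy atoms, in compound 1 meta to a group of 7 heavy atoms, so this is the same kind of change rather than the same change.

The expected step is a step that the limit leaves unreadable from compound 3 to compound 4, resting on the step that the two limits leave unreadable from compound 1 to compound 2 and on (the limit of > 200000 nM in this assay, at which 3 of the 3 values shown sit), at which every value of the series sits. Compound 4 is therefore expected to give 400000 nM, most probably reported as a limit again.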

Compound 4, half-maximal inhibitory concentration: > 200000 nM
Compound 4 ended at the assay's limit (the forecaster's own chance of this, stated with the estimate: 90%); the middle value lies beyond the limit too.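

In this assay compound 3 and compound 4 both end at a limit rather than a number, so no step can be read between them: the limit of > 200000 nM in this assay, at which 4 of the 4 values shown sit.

The compounds shown leave open whether hydrogen in place of iodo on the aromatic carbon has any effect on this read-out, on either core.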